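This account rests on a few compounds, and the source may have more. Where it says the series, first, only, none or still open, it means among the compounds named here.

In a functional assay on A549 cells (Homo sapiens) for inhibition, read by CCK-8 assay, with a stated time of 72 h, tested at 1 uM (on this read-out higher numbers stand for a stronger effect at the one concentration tested and lower numbers for a weaker effect), compound 1 `CN(C)C(=O)c1cc2cnc(Nc3ccc(S(=O)(=O)NCCCCN=C=S)cc3)nc2n1C1CCCC1` gives 39.4%, the highest of the three numbers measured. Compound 2 `CN(C)C(=O)c1cc2cnc(Nc3ccc(C(=O)NCCCN=C=S)cc3F)nc2n1C1CCCC1` gives 16.7% and compound 3 `CN(C)C(=O)c1cc2cnc(Nc3ccc(C(=O)NCCCCCCN=C=S)cc3F)nc2n1C1CCCC1` gives -11.8%, and both of these gaps below compound 1 are beyond the scatter. Going by the values given here, the one measured step between neighbouring structures, a number 28.5 percentage points lower from compound 2 to compound 3 (beyond the scatter), concerns a lengthening on the saturated chain and does not touch the part of the molecule changed here. Compound 4 `CN(C)C(=O)c1cc2cnc(Nc3ccc(N=C=S)cc3)nc2n1C1CCCC1` differs from compound 1 by a group of 3 heavy atoms (1 carbon, 1 nitrogen, 1 sulfur; no ring) in place of a group of 11 heavy atoms (5 carbon, 2 nitrogen, 2 oxygen, 2 sulfur; no ring), on an aromatic carbon. Among the compounds with values here, no measured step bears directly on such a change, so its direction is uncertain. A modest drop is nevertheless expected, a number 14.4 percentage points lower from compound 1 to compound 4 (beyond the scatter), with wide uncertainty. Compound 4 is therefore estimated at 25%, within a range from 0% to 50%.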

Compound 4, a percentage reported as inhibition, at one concentration (the size of the read-out at that concentration, not a potency): 44.4%
Beside the measured number, compound 4's estimate is 19.4 percentage points below it; the range from low to high includes it.
By their numbers in this assay, from the lowest: compound 3; then compound 2; then compounds 1 and 4 (each within the scatter of the next).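

Putting the group of 3 heavy atoms in place of the group of 11 heavy atoms on the aromatic carbon gives a number 5 percentage points higher from compound 1 to compound 4 (within the scatter) in this assay. Going by these compounds alone, at this position, therefore, the whole group of 11 heavy atoms, with its hydrogen-bond donor, can go without a change beyond the scatter, which the earlier compounds, all with a larger group on that ring, did not show. Nothing at hand explains this result. Still open, on these data alone, is whether the group of 3 heavy atoms itself is needed at this position. An amine or a carboxylic acid in its place would test that.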